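A Fluorine Swap Repeated on a Reduced Core

The source may hold more compounds than are shown below. What is called first, only, known or untested is meant among the compounds shown, and "the series" means these compounds.

Compound 1 `COc1cc(OC)cc([C@@H]2C(=O)c3cc(OC)cc(OC)c3[C@H]2c2ccccc2)c1` and compound 2 `COc1cc(OC)cc([C@@H]2C(=O)c3cc(OC)cc(OC)c3[C@H]2c2ccc(F)cc2)c1` share a core that carries a ketone, and compound 2 differs from compound 1 by fluoro in place of hydrogen on an aromatic carbon. In a functional assay on RAW264.7 cells (Mus musculus) for inhibition, with stated times of 2 h and 24 h (a higher number here means a weaker inhibitor, a lower number a stronger inhibitor), compound 1 gives 27100 nM, while compound 2 gives 44800 nM, a step recorded as a 1.7-fold higher number from compound 1 to compound 2 (0.22 log units; within the scatter). Compound 3 `COc1cc(OC)cc([C@@H]2C(O)c3cc(OC)cc(OC)c3[C@H]2c2ccccc2)c1` carries an alcohol where compound 1 carries the ketone; the difference between the two cores is not broken down here. In this assay compound 3 gives 3380 nM. Compound 4 `COc1cc(OC)cc([C@@H]2C(O)c3cc(OC)cc(OC)c3[C@H]2c2ccc(F)cc2)c1` has not yet been measured; it differs from compound 3 by fluoro in place of hydrogen on an aromatic carbon, the same change as from compound 1 to compound 2. The step expected from compound 3 to compound 4 in this assay is a 1.5-fold higher number from compound 3 to compound 4 (0.17 log units; within the scatter), resting on the earlier step being within the usual scatter. Compound 4 is therefore estimated at 5000 nM, between 2000 nM and 12000 nM.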

Compound 4, half-maximal inhibitory concentration: "not active" (no number reported)
Compound 4 has no reported number here; no gap can be computed for the estimate.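

In this assay, among the compounds shown here, compound 4 is reported as "not active", without a number, so no step from compound 3 to compound 4 can be read. Going by these compounds, how far compound 4 lies from compound 3 stays open. No available evidence bears on this result.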